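Removing a tert-butyl group from compound 3

The source may report more compounds than this note shows. Statements on the series, on what has been measured and on what is new or still open speak of the compounds shown alone.

Compound 1 `COc1cccc(C#Cc2c([N+](=O)[O-])nc3n2CC(C)O3)c1`: 6410 nM
Compound 2 `CC1Cn2c(nc([N+](=O)[O-])c2C#CC2CC2)O1`: 14800 nM
Compound 3 `CC1Cn2c(nc([N+](=O)[O-])c2C#Cc2ccc(C(C)(C)C)cc2)O1`: 4220 nM

These values come from an ADME assay on HepG2 cells (Homo sapiens) for cytotoxicity, read by MTT assay, with a stated time of 24 h; on this read-out higher numbers stand for lower toxicity in this test and lower numbers for higher toxicity in this test. Compound 3 and compound 1 lie within the usual scatter of repeated measurements, so the two cannot be told apart. Compound 2 shows a higher number than compound 3, and that gap lies beyond the scatter.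

Compound 4 `CC1Cn2c(nc([N+](=O)[O-])c2C#Cc2ccccc2)O1` has not yet been measured. It differs from compound 3 in one place: hydrogen in place of tert-butyl on an aromatic carbon. Going by the values given here, no measured pair shows this change on its own, so its size cannot be read directly from the data. Compound 1 gives 6410 nM and compound 3 gives 4220 nM, and both carry a six-membered aromatic ring, though with different groups on it. Compound 2 lacks that ring and gives 14800 nM. With only these compounds to go on, a small move towards a higher number seems likely, probably within the scatter. The expected step is a 1.7-fold higher number from compound 3 to compound 4 (0.22 log units; within the scatter). Compound 4 is estimated at 7000 nM, with an expected range of 3500 nM to 14000 nM.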

Compound 4, half-maximal cytotoxic concentration: 5400 nM
For compound 4 the middle estimate is 1.3-fold (0.11 log units) above the measured one, within the range that was stated.
By their numbers in this assay, from the lowest: compounds 3, 4 and 1 (each within the scatter of the next); then compound 2.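

In this assay, taking the tert-butyl group off the six-membered aromatic ring gives a 1.3-fold higher number from compound 3 to compound 4 (0.11 log units; within the scatter) and so leaves no change that can be told apart from repeat-measurement variation. Replacing the methoxy group of compound 1 with hydrogen gives a 1.2-fold lower number from compound 1 to compound 4 (0.07 log units; within the scatter) and likewise cannot be read as a real change, so in this small set neither group on the ring can be told apart from hydrogen. Going by these compounds alone, the one step beyond the scatter lies at the other place, the triple-bonded carbon, where phenyl in place of cyclopropyl gives a 2.7-fold lower number from compound 2 to compound 4 (0.44 log units; beyond the scatter) as the first single-place comparison showing that the group there can matter in this test, though the step is modest. No measurement available here explains any of these steps.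

The compounds shown leave open whether an amine or a carboxylic acid on the aromatic ring would shift the number beyond the scatter, as only tert-butyl and methoxy can be compared with hydrogen there. Also open, going by these compounds, is how a longer alkyl chain on the triple-bonded carbon would compare with cyclopropyl and phenyl.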